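Fluoro for chloro in a series near the assay limit

The source may report more compounds than this note shows. Statements on the series, on what has been measured and on what is new or still open speak of the compounds shown alone.

For the measured compounds named here, in a functional assay on SGC-7901 cells (Homo sapiens) for antiproliferative activity, read by MTT assay, with a stated time of 24 h (on this read-out higher numbers stand for weaker inhibition and lower numbers for stronger inhibition), compound 1 `O=C(NNc1ccccc1Cl)c1cccc(NS(=O)(=O)c2cnc(O)nc2O)c1` gives 2270 nM, the only measured number in this set. Compound 2 `Cc1ccccc1NNC(=O)c1ccccc1NS(=O)(=O)c1cnc(O)nc1O` reports only a limit, > 20000 nM. Compound 3 `O=C(NNc1ccccc1Cl)c1ccccc1NS(=O)(=O)c1cnc(O)nc1O` also reports only a limit, > 20000 nM. Compound 3 therefore stands at the limit of > 20000 nM in this assay, at which 2 of the 3 values shown sit, and offers no exact starting number.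

Compound 4 `O=C(NNc1ccccc1F)c1ccccc1NS(=O)(=O)c1cnc(O)nc1O` comes from compound 3 through one change, fluoro in place of chloro on an aromatic carbon. Going by the values given here, the one measured step at this place is a step that the two limits leave unreadable from compound 2 to compound 3. Its size cannot be read, so it provides no magnitude to carry over, but both of its compounds remain at the limit of this assay. On that basis, no step beyond the scatter is expected in either direction, and a further limit is the likeliest report. The estimated outcome is a step that the limit leaves unreadable from compound 3 to compound 4. For compound 4 the expected value is 25000 nM, with an estimated range of 9000 nM to 60000 nM.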

Compound 4, half-maximal inhibitory concentration: > 20000 nM
Compound 4 gave a limit, no number (the forecaster's own chance of this, stated with the estimate: 70%); the middle value does not contradict the limit.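

Compound 4 also reports only a limit, > 20000 nM, so the steps among compound 2, compound 3 and compound 4 cannot be read. It remains open whether fluoro, chloro and methyl on this aromatic carbon differ at all in this assay, as none of these compounds has an exact value.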